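Replacing the acetamidophenyl arm of compound 3

The compounds below may be only part of what the source reports. "The series", "measured", "known", "first", "only" and "open" are said of these compounds alone.

Compound 1 `COc1ccc(-n2nncc2CN2C(=O)C3(C(C#N)=C(N)Oc4c3c3nc5ccccc5nc3c3ccccc43)c3ccccc32)cc1`: in a functional assay on HCT-116 cells (Homo sapiens) for antiproliferative activity, read by MTT assay, with a stated time of 48 h (on this read-out higher numbers stand for weaker inhibition and lower numbers for stronger inhibition), compound 1 gives > 50000 nM, which is a limit of the assay.
Compound 2 `CCOc1ccc(-n2nncc2CN2C(=O)C3(C(C#N)=C(N)Oc4c3c3nc5ccccc5nc3c3ccccc43)c3ccccc32)cc1`: in this assay compound 2 gives > 50000 nM, also a limit.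
Compound 3 `CC(=O)Nc1ccc(-n2nncc2CN2C(=O)C3(C(C#N)=C(N)Oc4c3c3nc5ccccc5nc3c3ccccc43)c3ccccc32)cc1`: in this assay compound 3 gives > 50000 nM, again a limit.

Compound 3 therefore stands at the same limit as the other two measured compounds; the limit of > 50000 nM in this assay, at which 3 of the 3 values shown sit, summarises this. The steps among them, a step that the two limits leave unreadable from compound 1 to compound 2, a step that the two limits leave unreadable from compound 1 to compound 3 and a step that the two limits leave unreadable from compound 2 to compound 3, are all unreadable, because both ends of each step sit at the limit.

Compound 4 `N#CC1=C(N)Oc2c(c3nc4ccccc4nc3c3ccccc23)C12C(=O)N(Cc1cnnn1-c1cccc(S(N)(=O)=O)c1)c1ccccc12` differs from compound 3 by 3-sulfamoylphenyl in place of 4-acetamidophenyl on an aromatic nitrogen. Among the measured compounds shown here, none of the measured steps touches this position with a readable size, so there is no evidence that would point in either direction for this assay. Given that compound 3 sits at the limit, compound 4 is expected to stay close to it; the estimated step of a number no higher from compound 3 to compound 4 (the limit leaves the size open) is taken as no change beyond the scatter. Compound 4 is estimated at 50000 nM, within 10000 nM to 200000 nM, with a considerable chance that only a limit is reported.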

Compound 4, half-maximal inhibitory concentration: 11300 nM
For compound 4 the middle estimate is 4.4-fold (0.65 log units) above the measured one, within the range that was stated.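

In this assay the aryl arm on the aromatic nitrogen proves to be a place where a change can be read: 3-sulfamoylphenyl shows an at least 4.4-fold lower number from compound 3 to compound 4 (0.64 log units; beyond the scatter) against 4-acetamidophenyl, an at least 4.4-fold lower number from compound 2 to compound 4 (0.64 log units; beyond the scatter) against 4-ethoxyphenyl and an at least 4.4-fold lower number from compound 1 to compound 4 (0.64 log units; beyond the scatter) against 4-methoxyphenyl. Each of these sizes is only a lower bound, and the steps among the other three compounds still cannot be read. Compound 4 alone leaves the limit: the limit of > 50000 nM in this assay, at which 3 of the 4 values shown sit.

The compounds shown leave open whether the sulfamoyl group or its place on the ring carries the difference, a question that 4-sulfamoylphenyl or 3-acetamidophenyl would bear on. They also leave open whether another group at that place, such as 3-carboxyphenyl or 3-aminophenyl, would read the same way.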